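The source may report more compounds than this note shows. Statements on the series, on what has been measured and on what is new or still open speak of the compounds shown alone.

Three compounds of the series have numbers in a functional assay on CHO cells for activation of 5-hydroxytryptamine receptor 1D (Homo sapiens), read by GTPgammaS binding; a lower number here means a smaller maximal response, a higher number a larger maximal response. Compound 1 `O=S(=O)(NCC1CCN(CCCc2c[nH]c3ccc(-n4cnnc4)cc23)CC1)c1ccccc1` gives 73%; compound 2 `c1ccc(CNCC2CCN(CCCc3c[nH]c4ccc(-n5cnnc5)cc34)CC2)cc1` gives 101%; compound 3 `CN(Cc1cccs1)C1CCN(CCCc2c[nH]c3ccc(-n4cnnc4)cc23)CC1` gives 81%. Within this set compound 3 holds the second highest of the three numbers: its gap to compound 1 lies within the scatter, while the step of a number 20 percentage points lower from compound 2 to compound 3 (beyond the scatter) lies beyond it, so compound 2 alone stands apart.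

Compound 4 `O[C@@H]1Cc2ccccc2[C@H]1NC1CCN(CCCc2c[nH]c3ccc(-n4cnnc4)cc23)CC1` differs from compound 3 at the position where all three measured compounds vary: (2-hydroxy-2,3-dihydro-1H-inden-1-yl)amino in place of methyl((thiophen-2-yl)methyl)amino on a saturated ring carbon. Within the data shown here, two measured steps touch this position. The step of a number 8 percentage points higher from compound 1 to compound 3 (within the scatter) exchanges one substituent on the saturated ring carbon for another without a clear effect, whereas a number 28 percentage points higher from compound 1 to compound 2 (beyond the scatter) and a number 20 percentage points lower from compound 2 to compound 3 (beyond the scatter) show that a benzyl-bearing amine lifts the maximal response by a modest amount. Among the measured compounds shown here, the group entering in compound 4 brings one six-membered aromatic ring of carbon only and two hydrogen-bond donors; no measured compound covers such a change, so only a small step is expected, likely within the scatter. For compound 4 the expected step from compound 3 in this series is a number 4 percentage points higher from compound 3 to compound 4 (within the scatter). The value expected for compound 4 is 85%, with a range from 65% to 105%.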

Compound 4, largest response reached (reported as efficacy), in percent of the reference or control that the assay uses: 75%
The estimate for compound 4 lay 10 percentage points above the measured number, and the stated range covers the measured number.
By their numbers in this assay, from the lowest: compounds 1, 4 and 3 (each within the scatter of the next); then compound 2.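

In this assay, (2-hydroxy-2,3-dihydro-1H-inden-1-yl)amino on the saturated ring carbon gives no clear shift from methyl((thiophen-2-yl)methyl)amino, with a number 6 percentage points lower from compound 3 to compound 4 (within the scatter), so this position accepts a substituent with a five-membered non-aromatic ring of carbon only, a six-membered aromatic ring of carbon only, and 2 defined stereocentres. The comparison with ((phenylsulfonyl)amino)methyl is also within the scatter, with a number 2 percentage points higher from compound 1 to compound 4 (within the scatter), which places compound 1, compound 3 and compound 4 at one level despite their different substituents. Compound 2 remains apart, with a number 26 percentage points lower from compound 2 to compound 4 (beyond the scatter), so (benzylamino)methyl is the only group shown here whose number lies beyond the scatter from all the others.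

The data shown give no explanation for the separate level of compound 2. Still open, from the compounds shown here alone, is whether that level depends on the benzyl group or on its attachment through the methylene link, a question that benzylamino placed directly on the saturated ring carbon, or (2-phenylethylamino)methyl at the same place, would help to settle.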